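Replacing cyano with 3,4-dichlorophenyl in a series at its limit

This account rests on a few compounds, and the source may have more. Where it says the series, first, only, none or still open, it means among the compounds named here.

In a functional assay on HepG2 cells (Homo sapiens) for cytotoxicity, with a stated time of 72 h (a higher number here means that more compound is needed for the effect, a lower number that less compound is needed), compound 3 (`C=C[C@@](C)(/C=C/c1ccc(O)c(/C=C/C#N)c1)CCC=C(C)C`) reads > 52000 nM as a limit and not as a number. Compound 1 (`C=C[C@@](C)(/C=C/c1ccc(O)cc1)CC/C=C(C)/C=C/C(=O)OCC`) likewise gives only the limit > 52000 nM and no number. Compound 2 (`C=C[C@@](C)(/C=C/c1ccc(O)cc1)CC/C=C(C)/C=C/C(=O)OCc1ccccc1`) also gives only the limit > 52000 nM and no number. Among the compounds with values here, the series so far is summed up by the limit of > 52000 nM in this assay, at which 3 of the 3 values shown sit, and no compound yet carries a readable value.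

The change to compound 4 (`C=C[C@@](C)(/C=C/c1ccc(O)c(/C=C/c2ccc(Cl)c(Cl)c2)c1)CCC=C(C)C`) is 3,4-dichlorophenyl in place of cyano on a double-bonded chain carbon bound to a double-bonded chain carbon and it brings in a ring where compound 3 has none at that place. Within the data shown here, the only measured step is a step that the two limits leave unreadable from compound 1 to compound 2 and it also adds an aromatic ring, at another place in the structure, but it offers no size to carry over. Among the measured compounds shown here, no measured step therefore sets the size of this change. The expectation rests on compound 3 at its limit of > 52000 nM and points to a value near that limit, with a modest move to lower numbers possible. The estimated step is an at least 1.3-fold lower number from compound 3 to compound 4 (0.13 log units; that floor lies within the scatter) and remains an expectation measured against a limit. Compound 4 is estimated at 38000 nM in this assay with an expected range from 12000 nM to 52000 nM and a fair chance, by this expectation, of a limit and not a number.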

Compound 4, half-maximal effective concentration: > 52000 nM
Compound 4 ended at the assay's limit; the forecaster's own chance of this, stated with the estimate: 55%; at least 1.3-fold (0.13 log units) between middle value and limit.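

In this assay compound 3 gives > 52000 nM, a limit and not a number. Compound 4 gives > 52000 nM, also a limit, so no step can be read from compound 3 to compound 4. The series stays where it was: the limit of > 52000 nM in this assay, at which 4 of the 4 values shown sit. The compounds shown leave open what size the change from cyano to 3,4-dichlorophenyl has, and which structure would give a readable value.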